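Swapping a sulfonyl arm for chlorine on a quinone core

The compounds below may be only part of what the source reports. "The series", "measured", "known", "first", "only" and "open" are said of these compounds alone.

Measured compounds:
- compound 1 `Oc1c(Sc2ccccc2)c(Sc2ccccc2)c(O)c2ncccc12`: 6950 nM
- compound 2 `Cc1ccc(S(=O)(=O)C2=C(S(=O)(=O)c3ccc(C)cc3)C(=O)c3ncccc3C2=O)cc1`: 61600 nM

In a functional assay on HL-60 cells (Homo sapiens) for antiproliferative activity, read by MTT assay, with a stated time of 48 h (on this read-out lower numbers stand for stronger inhibition and higher numbers for weaker inhibition), compound 2 gives 61600 nM, the higher of the two numbers shown, and compound 1 gives 6950 nM, a gap beyond the usual scatter. Compound 3 `Cc1ccc(S(=O)(=O)C2=C(Cl)C(=O)c3ncccc3C2=O)cc1` has not yet been measured. It differs from compound 2 in one place: chloro in place of (4-methylphenyl)sulfonyl on a double-bonded ring carbon. For the measured compounds named here, no measured pair shows this change, so its effect is uncertain. A moderate drop in the number is expected, as a 4.1-fold lower number from compound 2 to compound 3 (0.61 log units; beyond the scatter). Compound 3 is estimated at 15000 nM, within 3000 nM to 60000 nM.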

Compound 3, half-maximal inhibitory concentration: 38100 nM
Compound 3: middle estimate off by 2.5-fold (0.40 log units), on the low side; low and high end bracket the measured number.
By their numbers in this assay, from the lowest: compound 1; then compounds 3 and 2 (each within the scatter of the next).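

In this assay, chloro in place of (4-methylphenyl)sulfonyl on a double-bonded ring carbon gives a 1.6-fold lower number from compound 2 to compound 3 (0.21 log units; within the scatter), so the two compounds cannot be told apart. At this position, then, a group with a six-membered aromatic ring can give way to a single chlorine without a clear shift in the read-out. Nothing measured here gives a reason for this result. On these data alone, whether an amine or a carboxylic acid on this carbon would give a clearly different number remains open. So does the effect of replacing the remaining (4-methylphenyl)sulfonyl group.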